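The source may hold more compounds than are shown below. What is called first, only, known or untested is meant among the compounds shown, and "the series" means these compounds.

Compound 3 `CCN(C/C=C/C#CC(C)(C)C)Cc1cccc(OCCN(C)S(=O)(=O)c2nccs2)c1` gives 170 nM in a functional assay on HepG2 cells for inhibition of squalene monooxygenase (Homo sapiens); a higher number here means a weaker inhibitor, a lower number a stronger inhibitor. Compound 2 `CCN(C/C=C/C#CC(C)(C)C)Cc1cccc(OCCN(C)S(=O)(=O)c2ccc(C#N)cc2)c1` gives 200 nM in this assay, and compound 1 `CCN(C/C=C/C#CC(C)(C)C)Cc1cccc(OCCN(C)S(=O)(=O)c2ccc(F)cc2)c1` gives 255 nM. The numbers of all three lie within the scatter of one another: a 1.2-fold lower number from compound 2 to compound 3 (0.07 log units; within the scatter) and a 1.5-fold lower number from compound 1 to compound 3 (0.18 log units; within the scatter). Compound 4 `CCN(C/C=C/C#CC(C)(C)C)Cc1cccc(OCCCS(=O)(=O)c2cccs2)c1` differs from compound 3 in that (a group of 9 heavy atoms (5 carbon, 2 oxygen, 2 sulfur; one five-membered aromatic ring with 1 hetero atom) in place of a group of 10 heavy atoms (4 carbon, 2 nitrogen, 2 oxygen, 2 sulfur; one five-membered aromatic ring with 2 hetero atoms), on a saturated chain carbon, two bonds along the chain from an oxygen on an aromatic ring). The measured steps that touch the same end of the molecule are the exchanges of the group on the sulfonyl sulfur, a 1.5-fold lower number from compound 1 to compound 3 (0.18 log units; within the scatter) and a 1.2-fold lower number from compound 2 to compound 3 (0.07 log units; within the scatter), and the exchange of a substituent on that group, a 1.3-fold lower number from compound 1 to compound 2 (0.11 log units; within the scatter), all within the scatter. Going by the values given here, no measured step replaces the sulfonamide nitrogen with a chain carbon, so that part of the change is untested. On the steps that are known, the step from compound 3 to compound 4 is expected to be small, a 1.3-fold higher number from compound 3 to compound 4 (0.11 log units; within the scatter), with no direction beyond the scatter. Compound 4 is therefore estimated at 220 nM in this assay, within a range from 80 nM to 600 nM.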

Compound 4, half-maximal inhibitory concentration: 290 nM
Compound 4: middle estimate off by 1.3-fold (0.12 log units), on the low side; the measured number falls inside the stated range.
By their numbers in this assay, from the lowest: compounds 3, 2, 1 and 4 (each within the scatter of the next).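

In this assay, going by these compounds alone, the first step to remove the sulfonamide nitrogen from the group on a saturated chain carbon, two bonds along the chain from an oxygen on an aromatic ring, stays within the scatter (a 1.7-fold higher number from compound 3 to compound 4 (0.23 log units; within the scatter)). This position therefore accepts a group with no nitrogen, with 3 hydrogen-bond acceptors in place of 4, and with a five-membered aromatic ring with 1 hetero atom in place of one with 2, without a step beyond the scatter. Nothing available accounts for the size of this step.

From the compounds shown here alone, the ring and the link change together here, so their separate contributions remain unknown. Also open, going by these compounds, is how this position would respond to a carbonyl in place of the sulfonyl group, or to a longer chain.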